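This account rests on a few compounds, and the source may have more. Where it says the series, first, only, none or still open, it means among the compounds named here.

Compound 1 `CC(C)=CCC/C(C)=C/COc1cc(=O)n(CCCO)c2c1CC(CC=C(C)C)C(C)(C)C2` gives 10.6%.
Compound 2 `CC(C)=CCC1Cc2c(OCCCNC(=O)c3cccs3)cc(=O)n(CCCO)c2CC1(C)C` gives 33.6%.
Compound 3 `CC(C)=CCC1Cc2c(OC(=O)Nc3cccc(F)c3)cc(=O)n(CCCO)c2CC1(C)C` gives 66.1%.

These numbers come from a functional assay on PANC-1 cells (Homo sapiens) for inhibition, read by MTT assay, with a stated time of 24 h, tested at 10 uM; a higher number here means more inhibition at the concentration tested (going by the name of the read-out), a lower number less inhibition. Compound 3 stands highest of the three: the step of a number 32.5 percentage points higher from compound 2 to compound 3 (beyond the scatter) and the step of a number 55.5 percentage points higher from compound 1 to compound 3 (beyond the scatter) are both beyond the scatter, while the step of a number 23 percentage points higher from compound 1 to compound 2 (beyond the scatter) is smaller. Compound 4 `CC(C)=CCC1Cc2c(OC(=O)Nc3cccc(C(F)(F)F)c3)cc(=O)n(CCCO)c2CC1(C)C` differs from compound 3 by a single change, (trifluoromethyl in place of fluoro on an aromatic carbon). For the measured compounds named here, no measured step alters a group on that six-membered ring; all three steps change what sits on the oxygen of the shared core, so none of them bears directly on this change. With nothing pointing either way, the step from compound 3 to compound 4 is expected to stay within the scatter, as a number 0.1 percentage points lower from compound 3 to compound 4 (within the scatter). Compound 4 is therefore estimated at 66%, within a range from 45% to 85%.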

Compound 4, a percentage reported as inhibition, at one concentration (the size of the read-out at that concentration, not a potency): 54.3%
Beside the measured number, compound 4's estimate is 11.7 percentage points above it, and the stated range covers the measured number.
By their numbers in this assay, from the lowest: compound 1; then compound 2; then compound 4; then compound 3.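

In this assay, for the compounds shown here, the earlier steps all changed what sits on the oxygen of the shared core, whereas this step changes a group on the six-membered aromatic ring itself. Trifluoromethyl in place of fluoro gives a number 11.8 percentage points lower from compound 3 to compound 4 (beyond the scatter) and so shows that the read-out responds to the group at this place, not only to the group on the oxygen. Nothing available here explains this drop.

Going by these compounds alone, with only two groups compared at this place, it remains open how a chloro, methoxy or amino group there would read. The compounds shown also leave open whether a trifluoromethyl elsewhere on the ring would give the same result.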